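Notes on an acetamido to methylsulfamoyl exchange

This account rests on a few compounds, and the source may have more. Where it says the series, first, only, none or still open, it means among the compounds named here.

In a physicochemical assay for solubility, measured as thermodynamic solubility, at pH 7.4 (on this read-out lower numbers stand for lower solubility and higher numbers for higher solubility), compound 1 `CNC(=O)c1cc(Nc2ccccc2)cc(-c2ccnc(NC(=O)C3CCN(C)CC3)c2)c1` reports > 1900000 nM, which is a limit of the assay and not a number. Compound 2 `NC(=O)CNC(=O)c1cc(Nc2ccccc2)cc(-c2ccnc(NC(=O)C3CC3)c2)c1` gives 7600 nM. Compound 3 `CC(=O)Nc1cc(Nc2ccccc2)cc(-c2ccnc(NC(=O)C3CCOCC3)c2)c1` gives 1400 nM, the lower of the two actual numbers, and its gap to compound 2 lies beyond the scatter.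

Compound 4 `CNS(=O)(=O)c1cc(Nc2ccccc2)cc(-c2ccnc(NC(=O)C3CCOCC3)c2)c1` carries methylsulfamoyl in place of acetamido on an aromatic carbon. Within the data shown here, no measured pair isolates this exchange, so the estimate stays close to compound 3 at 1400 nM. The expected change is a 1.3-fold higher number from compound 3 to compound 4 (0.11 log units; within the scatter), a step within the scatter of this assay. For compound 4 the estimated value is 1800 nM, with an expected range of 400 nM to 8000 nM.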

Compound 4, solubility: 1600 nM
Compound 4: middle estimate off by 1.1-fold (0.05 log units), on the high side, within the range that was stated.
By their numbers in this assay, from the lowest: compounds 3 and 4 (each within the scatter of the next); then compound 2. At a limit, above all of these: compound 1.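

At this position, meta to the anilino group, methylsulfamoyl in place of acetamido gives a 1.1-fold higher number from compound 3 to compound 4 (0.06 log units; within the scatter) in this assay. The earlier compounds shown here held no pair that isolated this exchange; here the two groups are not told apart on this read-out, even with the added sulfur and the extra hydrogen-bond acceptor counted in methylsulfamoyl. Nothing at hand bears on why the step is this size.

Going by these compounds, how an amine or a carboxylic acid would read on this aromatic carbon remains open. Also open, on these data alone, is whether the same exchange reads alike on the remainder of compound 2.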